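Dimethylpiperazine replacing methylpiperazine on the aryl amide

The compounds below may be only part of what the source reports. "The series", "measured", "known", "first", "only" and "open" are said of these compounds alone.

In a functional assay on KG-1 cells (Homo sapiens) for antiproliferative activity, read by CCK-8 assay, with a stated time of 72 h (on this read-out higher numbers stand for weaker inhibition and lower numbers for stronger inhibition), compound 2 `COc1ccc(F)c(-c2ccc3c(NC(=O)c4ccc(N5CCN(C)CC5)cc4)n[nH]c3c2)c1F` gives 41.5 nM, the lowest of the two numbers recorded so far. Among the compounds with values here, its only neighbour is compound 1 `COc1ccc(F)c(-c2ccc3c(NC(=O)c4ccc(N5CCN(C(C)=O)CC5)cc4)n[nH]c3c2)c1F`, which in this assay gives 595 nM; the change a 14-fold lower number from compound 1 to compound 2 (1.16 log units; beyond the scatter) is the single measured step available. Compound 3 `COc1ccc(F)c(-c2ccc3c(NC(=O)c4ccc(N5C[C@@H](C)N[C@@H](C)C5)cc4)n[nH]c3c2)c1F` is not yet measured. It differs from compound 2 by 3,5-dimethylpiperazin-1-yl in place of 4-methylpiperazin-1-yl on an aromatic carbon. Within the data shown here, no measured step shares this change: the one step recorded concerns the substituent on the distal ring nitrogen, not methyl groups on the ring carbons, so it offers only indirect guidance. Because compound 2 gives 41.5 nM with the same ring attachment retained, the estimate for compound 3 is a small step, expected as a 1.6-fold higher number from compound 2 to compound 3 (0.19 log units; within the scatter), plausibly within the scatter. The expected value for compound 3 in this assay is 65 nM, with a range from 20 nM to 220 nM.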

Compound 3, half-maximal inhibitory concentration: 348 nM
Compound 3: middle estimate off by 5.4-fold (0.73 log units), on the low side; measured number outside the range, above it.
By their numbers in this assay, from the lowest: compound 2; then compounds 3 and 1 (each within the scatter of the next).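

In this assay, an 8.4-fold higher number from compound 2 to compound 3 (0.92 log units; beyond the scatter) shows that this position, on an aromatic carbon para to a large group, does not tolerate every small piperazine: moving from 4-methylpiperazin-1-yl to 3,5-dimethylpiperazin-1-yl costs nearly as much as the acetyl change did. The a 1.7-fold lower number from compound 1 to compound 3 (0.23 log units; within the scatter) leaves 3,5-dimethylpiperazin-1-yl and 4-acetylpiperazin-1-yl indistinguishable here, and among these three compounds only the 4-methylpiperazin-1-yl of compound 2 gives a clearly lower number. Nothing available here speaks to the reason for these differences.

Compound 3 places methyl groups on the ring carbons and also has no methyl on the distal ring nitrogen, and the two changes cannot be told apart. On these data alone, whether 3,4,5-trimethylpiperazin-1-yl, 4-ethylpiperazin-1-yl or another stereoisomer of the dimethylpiperazine would recover the number of compound 2 remains open.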